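A few compounds are considered here, and "the series" means these few. Any claim that something is new, unique, unknown or untested is made for them only; others in the source may bear on it.

Compound 1 `O=C(CO[N+](=O)[O-])Nc1ccc(C(=O)/C=C/c2ccco2)cc1` gives 34% in a functional assay on the whole organism (strain albino) for inhibition, with Rattus norvegicus as the target, read by paw edema, with stated times of 30 min and 1 h, at a dose of 100 mg/kg by the oral route (a higher number here means more inhibition at the dose given (going by the name of the read-out), a lower number less inhibition), the lowest of the two numbers shown. Compound 2 `CC(O[N+](=O)[O-])C(=O)Nc1ccc(C(=O)/C=C/c2ccco2)cc1` gives 41% in this assay, and the step of a number 7 percentage points higher from compound 1 to compound 2 (within the scatter) lies within the scatter. Compound 3 `CC(=O)c1ccc(OCC(=O)Nc2ccc(C(=O)/C=C/c3ccco3)cc2)cc1` differs from compound 1 by 4-acetylphenyl in place of nitro on an oxygen on a saturated carbon. For the measured compounds named here, no measured step bears on this change: the one step available replaces hydrogen with methyl on a saturated chain carbon and leaves the group on the oxygen untouched. The step of a number 2 percentage points higher from compound 1 to compound 3 (within the scatter) is therefore expected to stay within the scatter. For compound 3 the estimated inhibition is 36%, with an expected range from 20% to 52%.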

Compound 3, a percentage reported as inhibition, in the whole organism at one dose (the size of the read-out at that dose, not a potency): 28%
For compound 3 the middle estimate is 8 percentage points above the measured one; the range from low to high includes it.
By their numbers in this assay, from the lowest: compounds 3, 1 and 2 (each within the scatter of the next, the first and the last beyond it).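

For the compounds shown here, the earlier compounds both carried nitro on this oxygen, so compound 3 is the first test of replacing it. With 4-acetylphenyl in place of nitro, on an oxygen on a saturated carbon, the result is a number 6 percentage points lower from compound 1 to compound 3 (within the scatter) in this assay, so a group of nine heavy atoms with an aromatic ring is not separated from nitro at this dose. Nothing available explains this result. The compounds shown leave open how a plain phenyl, an amine or a carboxylic acid on this oxygen would read, and whether methyl on the chain carbon would change the reading with 4-acetylphenyl present.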